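The compounds below may be only part of what the source reports. "The series", "measured", "known", "first", "only" and "open" are said of these compounds alone.

Working notes on the shared core of compound 1 `O=C(CCCCCCNC(=O)C(O)(O)C(F)(F)F)Nc1ccc(Br)cc1`, tested in a functional assay on HCT-116 cells (Homo sapiens) for inhibition, read by colorimetric assay, with a stated time of 3 days; a lower number here means a stronger inhibitor, a higher number a weaker inhibitor. Compound 1 gives 3130 nM, compound 2 `COc1ccccc1NC(=O)CCCCCCNC(=O)C(O)(O)C(F)(F)F` gives 10100 nM, and compound 3 `CC(=O)c1ccc(NC(=O)CCCCCCNC(=O)C(O)(O)C(F)(F)F)cc1` gives 12100 nM. Compound 3 stands at the high end of the three numbers; its gap to compound 2 is within the scatter, while compound 1 lies beyond it. Compound 4 `O=C(CCCCCCNC(=O)C(O)(O)C(F)(F)F)Nc1ccc(F)cc1` differs from compound 3 by fluoro in place of acetyl on an aromatic carbon, returning to a halogen on the ring as in compound 1. The step that bears on this is a 3.9-fold higher number from compound 1 to compound 3 (0.59 log units; beyond the scatter); the others, a 3.2-fold higher number from compound 1 to compound 2 (0.51 log units; beyond the scatter) and a 1.2-fold higher number from compound 2 to compound 3 (0.08 log units; within the scatter), change the whole ring. A step back toward compound 1 is expected, a 2.7-fold lower number from compound 3 to compound 4 (0.43 log units; beyond the scatter). Compound 4 is estimated at 4500 nM, between 1600 nM and 12000 nM.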

Compound 4, half-maximal inhibitory concentration: 7570 nM
Beside the measured number, compound 4's estimate is 1.7-fold (0.23 log units) below it, and the stated range covers the measured number.
By their numbers in this assay, from the lowest: compound 1; then compounds 4, 2 and 3 (each within the scatter of the next).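

Fluoro in place of acetyl on the aromatic carbon gives no separable difference, a 1.6-fold lower number from compound 3 to compound 4 (0.20 log units; within the scatter), and the same holds against the 2-methoxyphenyl analogue, a 1.3-fold lower number from compound 2 to compound 4 (0.13 log units; within the scatter). A halogen at this place therefore does not by itself match compound 1: the exchange of bromo for fluoro gives a 2.4-fold higher number from compound 1 to compound 4 (0.38 log units; beyond the scatter), so the identity of the halogen counts here. Nothing available explains this gap between bromo and fluoro. As far as these compounds go, whether chloro or an amine at this place would group with compound 1 or compound 4 remains open, as does the outcome of a longer chain in the shared core.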